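Trypsin counter-screen: compound 3 to compound 4

The source may hold more compounds than are shown below. What is called first, only, known or untested is meant among the compounds shown, and "the series" means these compounds.

In an assay on isolated protein for inhibition of Trypsin (Homo sapiens) (a lower number here means a stronger inhibitor, a higher number a weaker inhibitor), compound 3 `COc1ccc(-n2nc(C(F)(F)F)cc2C(=O)Cc2ccc(-c3ccccc3S(N)(=O)=O)cc2)cc1` gives only a limit, > 2500 nM. Compound 1 `CS(=O)(=O)c1ccccc1-c1ccc(CC(=O)c2cc(C(F)(F)F)nn2-c2ccc3onc(N)c3c2)c(F)c1` also sits at a limit in this assay, > 20000 nM. Compound 2 `CC(C(=O)c1cc(C(F)(F)F)nn1-c1ccc2onc(N)c2c1)c1ccc(-c2ccccc2S(C)(=O)=O)cc1F` likewise sits at a limit in this assay, > 20000 nM. Going by the values given here, the one recorded step, a step that the two limits leave unreadable from compound 1 to compound 2, cannot be read, both ends being limits. Compound 4 `Nc1noc2ccc(-n3nc(C(F)(F)F)cc3C(=O)Cc3ccc(-c4ccccc4S(N)(=O)=O)cc3)cc12` differs from compound 3 by a group of 10 heavy atoms (7 carbon, 2 nitrogen, 1 oxygen; one five-membered aromatic ring with 2 hetero atoms, one six-membered aromatic ring of carbon only) in place of a group of 8 heavy atoms (7 carbon, 1 oxygen; one six-membered aromatic ring of carbon only), on an aromatic nitrogen. Among the compounds with values here, no measured step matches this change, so no size can be taken from the series; the only bearing is the limit of > 20000 nM in this assay, at which 2 of the 3 values shown sit, shared by compound 1 and compound 2, which both carry the group that enters, alongside the limit of > 2500 nM in this assay, at which 1 of the 3 values shown sits, for compound 3. Compound 4 is therefore expected to stay at a limit in this assay, the step that the limit leaves unreadable from compound 3 to compound 4 being a loose estimate. The estimate for compound 4 is 30000 nM, range 5000 nM to 200000 nM.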

Compound 4, inhibition constant: > 20000 nM
Compound 4 gave a limit, no number; the forecaster's own chance of this, stated with the estimate: 85%; the middle value is on the limit's open side.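

Going by these compounds alone, compound 3 and compound 4 both stand at limits in this assay, so no step between them can be read. The compounds shown leave open the actual inhibition constant of each, as none gives a number.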